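Phenyl ring substituent exchange on the shared core

A few compounds are considered here, and "the series" means these few. Any claim that something is new, unique, unknown or untested is made for them only; others in the source may bear on it.

Compound 1 `CCOC(=O)c1c(-c2cccc(OCc3ccccc3)c2)[nH]c2cc(OC)ccc2c1=O` and compound 2 `CCOC(=O)c1c(-c2cccc(F)c2)[nH]c2cc(OC)ccc2c1=O` share one core and differ only in the group on the pendant phenyl ring. In an ADME assay on Raji cells (Homo sapiens) for cytotoxicity, read by luminescence, with a stated time of 72 h (a higher number here means that more compound is needed for the effect, a lower number that less compound is needed), compound 1 gives only a limit of the assay, > 21500 nM. In this assay compound 2 also gives only a limit of the assay, > 21500 nM. For the measured compounds named here, the single measured step, a step that the two limits leave unreadable from compound 1 to compound 2, is therefore not readable in size, and compound 2 stands at the limit with no number of its own; the limit of > 21500 nM in this assay, at which 2 of the 2 values shown sit, holds both measured values.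

Compound 3 `CCOC(=O)c1c(-c2cccc(O)c2)[nH]c2cc(OC)ccc2c1=O` differs from compound 2 by hydroxy in place of fluoro on an aromatic carbon. Going by the values given here, no measured step follows a hydroxy group, and because the limit of > 21500 nM in this assay, at which 2 of the 2 values shown sit, places every measured value at the limit, no direction can be read from the series. Compound 3 is expected to give 30000 nM, with a range from 12000 nM to 100000 nM. The expected step is a step that the limit leaves unreadable from compound 2 to compound 3, no shift beyond the scatter, and most likely another limit.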

Compound 3, half-maximal effective concentration: > 21500 nM
Compound 3: no number, only a limit; the forecaster's own chance of this, stated with the estimate: 85%; the middle value does not contradict the limit.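

No step can be read from compound 1 or compound 2 to compound 3 in this assay, as all three values are limits of the assay: the limit of > 21500 nM in this assay, at which 3 of the 3 values shown sit.

The compounds shown leave open whether any group on the pendant phenyl ring gives a half-maximal effective concentration with a number of its own.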